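Working notes on the step to compound 4

This account rests on a few compounds, and the source may have more. Where it says the series, first, only, none or still open, it means among the compounds named here.

compound 1 `Cc1cc(S(N)(=O)=O)ccc1NC(=O)COc1ccc(Cl)cc1NC(=O)c1cccc(Cl)c1`: 59700 nM
compound 2 `Cc1ccc(C)c(C(=O)Nc2cc(Cl)ccc2OCC(=O)Nc2ccc(S(N)(=O)=O)cc2C)c1`: 79700 nM
compound 3 `Cc1cc(S(N)(=O)=O)ccc1NC(=O)COc1ccc(Cl)cc1NC(=O)c1cc(Cl)ccc1Cl`: 42100 nM

In a functional assay on C8166 cells (Homo sapiens) for cytotoxicity, read by MTT assay (a lower number here means that less compound is tolerated, a higher number that more compound is tolerated), compound 3 is not separated from the other two measured compounds. The steps that reach it are a 1.4-fold lower number from compound 1 to compound 3 (0.15 log units; within the scatter) and a 1.9-fold lower number from compound 2 to compound 3 (0.28 log units; within the scatter).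

The next structure is compound 4 `Cc1cc(S(N)(=O)=O)ccc1NC(=O)COc1ccc(Cl)cc1NC(=O)/C=C/c1ccccc1`, which carries 2-phenylethenyl in place of 2,5-dichlorophenyl on a carbonyl carbon.

The most relevant evidence comes from the exchanges at this same carbonyl carbon. Those steps are a 1.3-fold higher number from compound 1 to compound 2 (0.13 log units; within the scatter), together with the two steps into compound 3 given above. For the measured compounds named here, all three stay small, but each keeps an aromatic ring directly on the carbonyl carbon, and no measured compound carries 2-phenylethenyl, so the range is kept wide.

No step beyond the scatter is therefore expected in this assay, and no direction can be firmly assigned. The expected step is a 1.3-fold higher number from compound 3 to compound 4 (0.12 log units; within the scatter). The estimated value for compound 4 is 55000 nM, with an expected range of 25000 nM to 110000 nM.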

Compound 4, half-maximal cytotoxic concentration: 163000 nM
Beside the measured number, compound 4's estimate is 3.0-fold (0.47 log units) below it; the whole stated range lies below it.
By their numbers in this assay, from the lowest: compounds 3, 1 and 2 (each within the scatter of the next); then compound 4.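

In this assay this carbonyl carbon now gives steps beyond the scatter: a 3.9-fold higher number from compound 3 to compound 4 (0.59 log units; beyond the scatter) and a 2.0-fold higher number from compound 2 to compound 4 (0.31 log units; beyond the scatter) and also a 2.7-fold higher number from compound 1 to compound 4 (0.44 log units; beyond the scatter). For the compounds shown here, the three exchanges among 2,5-dichlorophenyl, 2,5-dimethylphenyl and 3-chlorophenyl all stayed within the scatter, so 2-phenylethenyl is the first group at this place to separate a compound from the others, and compound 4 is tolerated at the highest concentration of the four. Nothing available explains this difference.

A 2-phenylethyl group or an unsubstituted phenyl on the same carbonyl carbon would show whether the double bond outside the aromatic ring goes with the higher number, or whether the absence of substituents on the ring does. From the compounds shown here alone, whether a chloro on the ring of the 2-phenylethenyl group would keep that number also stays open.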